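Methylamino in place of methoxy: an estimate for compound 4

The source may hold more compounds than are shown below. What is called first, only, known or untested is meant among the compounds shown, and "the series" means these compounds.

In a functional assay for inhibition, with Homo sapiens as the target (on this read-out higher numbers stand for weaker inhibition and lower numbers for stronger inhibition), three compounds of a shared core have been measured:
compound 1, `CCc1ccc(Nc2nccc(-c3ccccn3)n2)cc1`, 2100 nM
compound 2, `CN(C)c1ccc(Nc2nccc(-c3ccccn3)n2)cc1`, 3300 nM
compound 3, `COc1ccc(Nc2nccc(-c3ccccn3)n2)cc1`, 8300 nM

Compound 3 gives the highest number of the three. The step of a 4.0-fold higher number from compound 1 to compound 3 (0.60 log units; beyond the scatter) and the step of a 2.5-fold higher number from compound 2 to compound 3 (0.40 log units; beyond the scatter) are both beyond the scatter, whereas the step of a 1.6-fold higher number from compound 1 to compound 2 (0.20 log units; within the scatter) is not, so compound 1 and compound 2 cannot be ordered against each other on these numbers, while compound 3 sits clearly above both.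

Compound 4, `CNc1ccc(Nc2nccc(-c3ccccn3)n2)cc1`, has not yet been measured in this assay. It differs from compound 3 in one place: methylamino in place of methoxy on an aromatic carbon. The measured step that bears most directly on this change is a 2.5-fold higher number from compound 2 to compound 3 (0.40 log units; beyond the scatter), since compound 2 carries a nitrogen-linked group on the same aromatic carbon and the methoxy of compound 3 gives the weaker result. Among the compounds with values here, compound 4 carries a nitrogen-linked group too, so a modest step back toward the number of compound 2 is expected, though the single comparison leaves the size uncertain.

The estimate for compound 4 in this assay is therefore 4000 nM, expected to fall between 1500 nM and 12000 nM, which means an expected step of a 2.1-fold lower number from compound 3 to compound 4 (0.32 log units; beyond the scatter).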

Compound 4, half-maximal inhibitory concentration: 1400 nM
Beside the measured number, compound 4's estimate is 2.9-fold (0.46 log units) above it; the whole stated range lies above it.
By their numbers in this assay, from the lowest: compounds 4, 1 and 2 (each within the scatter of the next, the first and the last beyond it); then compound 3.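

In this assay, methylamino in place of methoxy on the aromatic carbon para to a large group gives a 5.9-fold lower number from compound 3 to compound 4 (0.77 log units; beyond the scatter) and shows that this position responds to the exchange of the linking atom within a group of the same heavy-atom size. It also shows that the two nitrogen-linked groups do not read alike: hydrogen in place of methyl on the nitrogen gives a 2.4-fold lower number from compound 2 to compound 4 (0.37 log units; beyond the scatter) and so separates compound 4 from compound 2 beyond the scatter. Methylamino in place of ethyl gives a 1.5-fold lower number from compound 1 to compound 4 (0.18 log units; within the scatter) and lies within the scatter, so compound 1 and compound 4 cannot be ordered, and compound 3, with its methoxy, remains the weakest of the four.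

The compounds shown leave open whether an unsubstituted amino group or a longer chain on the nitrogen, such as ethylamino, would keep the number of compound 4 or move it. They also leave open how a hydroxyl group on the same carbon would compare with the methoxy of compound 3 and the methylamino of compound 4. Nothing available here accounts for these differences.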